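The compounds below may be only part of what the source reports. "The series", "measured", "known", "first", "only" and "open" are said of these compounds alone.

In a functional assay on cells (Platelet, Homo sapiens) for inhibition (a lower number here means a stronger inhibitor, a higher number a weaker inhibitor), compound 1 (`CCOC(=O)c1cccc(-c2n[nH]c3ccccc23)c1`) gives 5650 nM while compound 2 (`CCOC(=O)c1ccc(-c2nn(Cc3cccc(Cl)c3)c3ccccc23)cc1`) gives 80 nM and compound 3 (`CCOC(=O)c1ccc(-c2nn(Cc3ccc(Cl)cc3)c3ccccc23)cc1`) gives 120 nM on the same read-out. Compound 3 therefore sits level with compound 2, within the scatter, and both lie far under compound 1. Compound 1 differs from the other two in more than one place, so its gap offers no guide to a small change on the ring.

The next compound, compound 4 (`CCOC(=O)c1ccc(-c2nn(Cc3ccc(F)cc3)c3ccccc23)cc1`), has fluoro in place of chloro on an aromatic carbon, para to a large group (fluoro in place of chloro on an aromatic carbon). In other words, 4-chlorobenzyl becomes 4-fluorobenzyl. For the measured compounds named here, no measured pair makes this exact swap, so the evidence is indirect. The nearest measured step is a 1.5-fold higher number from compound 2 to compound 3 (0.18 log units; within the scatter), where only the place of the chloro changes on that same ring, and it stays within the scatter. On that single step, no change beyond the scatter is expected in this assay, in either direction. The estimated step is a 1.3-fold higher number from compound 3 to compound 4 (0.10 log units; within the scatter), which would leave the two compounds level. For compound 4 the estimated value is 150 nM, with an expected range of 50 nM to 450 nM for the measurement.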

Compound 4, half-maximal inhibitory concentration: 190 nM
For compound 4 the middle estimate is 1.3-fold (0.10 log units) below the measured one; low and high end bracket the measured number.
By their numbers in this assay, from the lowest: compounds 2, 3 and 4 (each within the scatter of the next, the first and the last beyond it); then compound 1.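

In this assay, for the compounds shown here, this is the first direct comparison of two halogens at the same spot, on an aromatic carbon para to a large group: 4-chlorobenzyl becomes 4-fluorobenzyl, and a 1.6-fold higher number from compound 3 to compound 4 (0.20 log units; within the scatter) leaves the two compounds level. The step that changes both the halogen and its place on the ring, a 2.4-fold higher number from compound 2 to compound 4 (0.38 log units; beyond the scatter), is the first among these ring changes to pass beyond the scatter, though only modestly, and with compound 3 level with both of the others, the gap cannot be assigned to the halogen or to its place alone. Nothing available explains these numbers in terms of a measured property of the groups.

The compounds shown carry only chloro or fluoro on this ring, so it remains open how a methoxy group, a trifluoromethyl group or plain hydrogen at the same spot would read in this assay. Compounds 2, 3 and 4 also share the same ethyl ester, which leaves open what a carboxylic acid or an amide in its place would give.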